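Two Weak Inhibitors and a New Carbonyl Chain

The source may hold more compounds than are shown below. What is called first, only, known or untested is meant among the compounds shown, and "the series" means these compounds.

- compound 1 `COc1ccc(CSc2nnc(-c3cc(OC)c(OC)c(OC)c3)n2-c2ccc(OC)cc2)cc1` gives 41100 nM
- compound 2 `COc1ccc(-n2c(SCc3ccc(F)cc3)nnc2-c2cc(OC)c(OC)c(OC)c2)cc1` gives 35000 nM

Going by the values given here, in a functional assay on HepG2 cells (Homo sapiens) for inhibition, read by MTT assay, with a stated time of 48 h (on this read-out higher numbers stand for weaker inhibition and lower numbers for stronger inhibition), compound 2 stands at 35000 nM and lies within the scatter of compound 1, the only other measured compound. Compound 3 `COc1ccc(C(=O)CSc2nnc(-c3cc(OC)c(OC)c(OC)c3)n2-c2ccc(OC)cc2)cc1` differs from compound 2 by (4-methoxyphenyl)carbonyl in place of 4-fluorophenyl on a saturated chain carbon bound to a sulfur in the structure. Among the compounds with values here, the one measured step (a 1.2-fold lower number from compound 1 to compound 2 (0.07 log units; within the scatter)) is small, but it only put fluoro in place of methoxy on an aromatic carbon, so it bears on this change weakly. The expected step (a 1.1-fold lower number from compound 2 to compound 3 (0.03 log units; within the scatter)) therefore stays within the scatter, with no clear direction. For compound 3 the estimated value is 33000 nM (expected range 11000 nM to 90000 nM).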

Compound 3, half-maximal inhibitory concentration: 18100 nM
Beside the measured number, compound 3's estimate is 1.8-fold (0.26 log units) above it; low and high end bracket the measured number.
By their numbers in this assay, from the lowest: compounds 3, 2 and 1 (each within the scatter of the next, the first and the last beyond it).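

In this assay, going by these compounds alone, the carbonyl on a saturated chain carbon bound to a sulfur gives a 2.3-fold lower number from compound 1 to compound 3 (0.36 log units; beyond the scatter) and is the first change here to pass the scatter, though only modestly. Measured against the 4-fluorophenyl group, the same position gives a 1.9-fold lower number from compound 2 to compound 3 (0.29 log units; within the scatter) so that step alone shows no clear change. Nothing measured here explains the modest difference. Still open, as far as these compounds go, is whether the carbonyl must carry an aromatic ring, or whether a carboxylic acid or an amine at this position would give a lower number.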